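The compounds below may be only part of what the source reports. "The series", "measured", "known", "first", "only" and "open" are said of these compounds alone.

Within the data shown here, compound 1 `CCN(c1ccc(C#N)c(Cl)c1)c1cc(-c2ccncc2)ccc1C` is the only member of this set for which a number exists. In a functional assay on CWR22R cells (Homo sapiens) for antiproliferative activity, read by CCK-8 assay, with a stated time of 6 days (on this read-out higher numbers stand for weaker inhibition and lower numbers for stronger inhibition), compound 1 gives 1030 nM. Compound 2 `CCN(c1cccc(-c2ccccc2)c1)c1ccc(C#N)c(Cl)c1` and compound 3 `N#Cc1ccc(N2CCc3cc(-c4cncnc4)ccc32)cc1C(F)(F)F` belong to the same set, but in this assay compound 2 shows "not determined" (no result reported) and compound 3 shows "not determined" (no result reported), so compound 1 stands alone on the numbers shown. Compound 4 `CCN(c1ccc(C#N)c(Cl)c1)c1cc(-c2ccnn2C)ccc1C` has not yet been measured. It differs from compound 1 in one place: 1-methyl-1H-pyrazol-5-yl in place of pyridin-4-yl on an aromatic carbon. Among the measured compounds shown here, no pair of measured compounds shows how such a swap moves the read-out, so no direction can be taken from the data. The step of a 1.5-fold higher number from compound 1 to compound 4 (0.16 log units; within the scatter) is expected to be small, not clearly beyond the scatter. Compound 4 is estimated at 1500 nM in this assay, with a range from 400 nM to 6000 nM.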

Compound 4, half-maximal inhibitory concentration: 4330 nM
The estimate for compound 4 lay 2.9-fold (0.46 log units) below the measured number, and the stated range covers the measured number.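

Among these compounds, this is the first measured change on this aromatic carbon, para to a methyl group, and it shows that the carbon is sensitive to which ring it carries. In this assay, 1-methyl-1H-pyrazol-5-yl in place of pyridin-4-yl gives a 4.2-fold higher number from compound 1 to compound 4 (0.62 log units; beyond the scatter), a modest loss of inhibition, although both groups have 6 heavy atoms and no net charge. Nothing shown explains this loss. The compounds cannot separate the effects of ring size, hetero atoms and the methyl on the new ring. Going by these compounds, it also remains open how an amine or a carboxylic acid would behave on this carbon.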